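Hydroxy on the amide nitrogen: compound 2 to compound 3

The compounds below may be only part of what the source reports. "The series", "measured", "known", "first", "only" and "open" are said of these compounds alone.

Measured so far:
Compound 1, `CCOc1ccc(Br)cc1-c1cc(Nc2ccc(B(O)O)cc2)nc(N)n1`: 91 nM
Compound 2, `CCOc1ccc(Br)cc1-c1cc(Nc2ccc(C(N)=O)cc2)nc(N)n1`: 750 nM

Both compounds share one core and differ only in the group on the outer aromatic ring. In an assay on Sf9 cells for inhibition of 1-acyl-sn-glycerol-3-phosphate acyltransferase beta (Homo sapiens) (a higher number here means a weaker inhibitor, a lower number a stronger inhibitor), compound 1 gives 91 nM, and compound 2, with carbamoyl in that place, gives 750 nM, so that an 8.2-fold higher number from compound 1 to compound 2 (0.92 log units; beyond the scatter). Within the data shown here, on the two numbers known, compound 2 stands as the weaker of the pair.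

Compound 3, `CCOc1ccc(Br)cc1-c1cc(Nc2ccc(C(=O)NO)cc2)nc(N)n1`, keeps the carbamoyl group of compound 2 and changes it only in one spot: hydroxy in place of hydrogen on an amide-type nitrogen. Among the measured compounds shown here, no measured step touches this amide nitrogen; the single step in hand, from compound 1 to compound 2, concerns the exchange of the whole group on the ring and does not tell how a hydroxy on the amide nitrogen will behave. The expectation therefore rests on little, and a change that stays within the scatter, or a modest one in either direction, is what can be said. On balance, compound 3 is estimated to give 450 nM in this assay, within a range of 120 nM to 1700 nM, which corresponds to an expected step of a 1.7-fold lower number from compound 2 to compound 3 (0.22 log units; within the scatter).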

Compound 3, half-maximal inhibitory concentration: 88 nM
For compound 3 the middle estimate is 5.1-fold (0.71 log units) above the measured one; measured number below the stated range.
By their numbers in this assay, from the lowest: compounds 3 and 1 (each within the scatter of the next); then compound 2.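

A single added oxygen is enough to change the picture at this amide nitrogen: in this assay the step is an 8.5-fold lower number from compound 2 to compound 3 (0.93 log units; beyond the scatter) and it shows that the group's outer end matters, which the earlier exchange of the whole group could not show. The result also shows that the carbamoyl group need not stay the weaker option on this aromatic carbon, since the hydroxycarbamoyl group reaches the level of the boronic acid group, with a step of a 1.0-fold lower number from compound 1 to compound 3 (0.01 log units; within the scatter) that leaves the two side by side with no order between them. Nothing measured here explains why the hydroxy has this effect.

As far as these compounds go, it remains open whether the hydroxy itself is needed or whether another group on the same amide nitrogen, such as methoxy, methyl or amino, would give a similar number. From the compounds shown here alone, it is also open how a carboxylic acid in place of the whole group would compare, and whether hydroxy on this nitrogen would have the same effect on a different core.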